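The compounds below may be only part of what the source reports. "The series", "measured", "known", "first", "only" and "open" are said of these compounds alone.

Compound 1, `CC(C)N(Cc1cccc(OCCCCCC(=O)O)c1)C(=O)c1ccc(-c2ccoc2)cc1`: in an ADME assay on HepG2 cells (Homo sapiens) for cytotoxicity, read by CellTiter-Glo and resazurin assay, with a stated time of 72 h (a higher number here means that more compound is needed for the effect, a lower number that less compound is needed), compound 1 gives > 26000 nM, a limit of the assay.
Compound 2, `CC(C)Oc1cccc(-c2ccc(C(=O)N(Cc3cccc(OCCCCCC(=O)O)c3)C(C)C)cc2)c1`: in this assay compound 2 gives > 26000 nM, also a limit.
Compound 3, `CCOC(=O)CCCCCOc1cccc(CN(C(=O)c2ccc(-c3ccoc3)cc2)C(C)C)c1`: in this assay compound 3 gives > 26000 nM, again a limit.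

Compound 4, `CCOC(=O)CCCCCOc1cccc(CN(C(=O)c2ccc(-c3cccc(OC(C)C)c3)cc2)C(C)C)c1`, has not yet been measured. It differs from compound 3 by 3-isopropoxyphenyl in place of furan-3-yl on an aromatic carbon. The same change, at the same place word for word, has already been made from compound 1 to compound 2: 3-isopropoxyphenyl in place of furan-3-yl on an aromatic carbon, with a step that the two limits leave unreadable from compound 1 to compound 2. The two cores differ by ethyl in place of hydrogen on an oxygen next to a carbonyl group, and that step reads a step that the two limits leave unreadable from compound 1 to compound 3. All three measured values sit at the limit of > 26000 nM in this assay, at which 3 of the 3 values shown sit, so neither step can be sized, and nothing in these data separates the compounds from one another.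

The step from compound 3 to compound 4 is therefore expected to be a step that the limit leaves unreadable from compound 3 to compound 4, resting on the unreadable step from compound 1 to compound 2 and on (the limit of > 26000 nM in this assay, at which 3 of the 3 values shown sit). Compound 4 is accordingly estimated at 40000 nM, most likely again reported as a limit, with a range from 15000 nM to 120000 nM.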

Compound 4, half-maximal effective concentration: > 26000 nM
Compound 4: only a limit was reported; the forecaster's own chance of this, stated with the estimate: 80%; the middle value lies beyond the limit too.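

In this assay compound 4 gives > 26000 nM, which is a limit, so the steps to it from compound 3 and from compound 2 cannot be read, and all four compounds remain unseparated: the limit of > 26000 nM in this assay, at which 4 of the 4 values shown sit.

The compounds shown leave open how large either change is, and at what concentration any of the four compounds would reach the half-maximal effect.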